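The source may hold more compounds than are shown below. What is called first, only, known or untested is meant among the compounds shown, and "the series" means these compounds.

Measured so far:
Compound 1, `Oc1cccc(-c2cc(-c3ccc(Cl)cc3)nc(-c3ccco3)c2)c1`, in a functional assay on DU-145 cells (Homo sapiens) for cytotoxicity, read by CCK-8 assay and cell counting, with a stated time of 2 days (on this read-out higher numbers stand for weaker inhibition and lower numbers for stronger inhibition), gives 11400 nM.
Compound 2, `Oc1cccc(-c2cc(-c3ccsc3)nc(-c3ccccc3Cl)c2)c1`, in this assay gives 1970 nM.

Compound 2 holds the lower of the two numbers; compound 1 sits higher by a margin beyond the usual scatter. Among the compounds with values here, the two compounds differ in more than one place, so no single step between them can be drawn.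

Compound 3, `Oc1cccc(-c2cc(-c3ccco3)nc(-c3ccccc3Cl)c2)c1`, differs from compound 2 in one place: furan-2-yl in place of thiophen-3-yl on an aromatic carbon. Compound 1 also carries furan-2-yl and gives the higher number, but its second difference from compound 2 leaves that comparison uncertain. On this thin basis a modest step toward weaker inhibition is expected, near the edge of the scatter, as a 1.8-fold higher number from compound 2 to compound 3 (0.25 log units; within the scatter). Compound 3 is therefore estimated at 3500 nM in this assay, with a range from 1200 nM to 12000 nM.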

Compound 3, half-maximal inhibitory concentration: 1630 nM
The estimate for compound 3 lay 2.1-fold (0.33 log units) above the measured number, and the stated range covers the measured number.
By their numbers in this assay, from the lowest: compounds 3 and 2 (each within the scatter of the next); then compound 1.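

In this assay, furan-2-yl in place of thiophen-3-yl on the aromatic carbon next to the ring nitrogen gives a 1.2-fold lower number from compound 2 to compound 3 (0.08 log units; within the scatter), so this position shows no difference between these two five-membered aromatic rings. Within the data shown here, the same result also provides the first comparison in which only the chlorophenyl group differs: with furan-2-yl held constant, 2-chlorophenyl in place of 4-chlorophenyl gives a 7.0-fold lower number from compound 1 to compound 3 (0.84 log units; beyond the scatter), a step beyond the scatter that shows the placement of the chlorine matters here. No supporting data are available to explain either step.

The compounds shown leave open whether 3-chlorophenyl or plain phenyl would fit the same trend as the two chlorophenyl groups. They also leave open whether a non-aromatic group, such as a morpholine or a simple amine, would be tolerated where furan-2-yl and thiophen-3-yl sit.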